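Shared core series: amine substituent swap at the chain nitrogen

The compounds below may be only part of what the source reports. "The series", "measured", "known", "first", "only" and "open" are said of these compounds alone.

Compound 1, `NC(=O)CCCN(Cc1cccc(C(N)=O)c1)C[C@H]1O[C@@H](n2cnc3c(N)ncnc32)[C@H](O)[C@@H]1O`, gives > 250000 nM in an assay on cells for inhibition of Nicotinamide N-methyltransferase (Homo sapiens), with stated times of 10 min and 30 min (a lower number here means a stronger inhibitor, a higher number a weaker inhibitor), a limit of the assay.
Compound 2, `NC(=O)c1cccc(CN(CCCCC(=O)O)C[C@H]2O[C@@H](n3cnc4c(N)ncnc43)[C@H](O)[C@@H]2O)c1`, gives > 250000 nM in this assay, again a limit.

The step that the two limits leave unreadable from compound 1 to compound 2 cannot be sized, since both values rest at the limit of > 250000 nM in this assay, at which 2 of the 2 values shown sit. Compound 3, `CC(C)N(Cc1cccc(C(N)=O)c1)C[C@H]1O[C@@H](n2cnc3c(N)ncnc32)[C@H](O)[C@@H]1O`, differs from compound 2 by isopropyl in place of 4-carboxybutyl on an amine nitrogen. Among the compounds with values here, no measured step bears on this change; the single step in the set is unreadable, so no direction can be drawn from it. Compound 3 is therefore expected to remain weak, with the step of an at least 1.6-fold lower number from compound 2 to compound 3 (0.22 log units; that floor lies within the scatter) expected to be small. The estimate for compound 3 in this assay is 150000 nM, with a range from 30000 nM to 300000 nM.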

Compound 3, half-maximal inhibitory concentration: > 250000 nM
Compound 3 was reported as a limit; the forecaster's own chance of this, stated with the estimate: 50%; middle value at least 1.6-fold (0.22 log units) from the limit.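

Compound 3 ends at a limit, as do compound 1 and compound 2, so no step among the three can be read: the limit of > 250000 nM in this assay, at which 3 of the 3 values shown sit.

Going by these compounds, whether any group on the amine nitrogen gives a measurable value in this assay stays open.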